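The source may hold more compounds than are shown below. What is called first, only, known or untested is meant among the compounds shown, and "the series" means these compounds.

For the measured compounds named here, compound 1 `Nc1ccc(Nc2c(C(=O)NCc3ccc(F)cc3)nc(Br)c3cccnc23)cc1` is the only compound with a numerical result here. In a functional assay on HCT-116 cells (Homo sapiens) for cytotoxicity, read by MTT assay, with a stated time of 72 h (on this read-out lower numbers stand for stronger inhibition and higher numbers for weaker inhibition), compound 1 gives 7000 nM. Compound 2 `C[C@@H](CO)Nc1nc(C(=O)NCc2ccc(F)cc2)c(O)c2ncccc12` belongs to the same series, but in this assay compound 2 gives "not determined" (no result reported). Compound 3 `Cc1ccc(S(=O)(=O)Oc2c(C(=O)NCc3ccc(F)cc3)nc(Br)c3cccnc23)cc1` differs from compound 1 by the change (((4-methylphenyl)sulfonyl)oxy in place of (4-aminophenyl)amino on an aromatic carbon). Going by the values given here, no measured pair shows how such a change plays out, so the step from compound 1 to compound 3 is expected to be small, within or just beyond the scatter, toward weaker inhibition, as a 2.1-fold higher number from compound 1 to compound 3 (0.33 log units; beyond the scatter). For compound 3 the estimated value is 15000 nM, likely falling between 5000 nM and 50000 nM.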

Compound 3, half-maximal inhibitory concentration: > 20000 nM
Compound 3 was reported as a limit (the forecaster's own chance of this, stated with the estimate: 30%); middle value at least 1.3-fold (0.12 log units) away from the limit.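

In this assay, compound 3 gives > 20000 nM, which is a limit and not a number. Placing ((4-methylphenyl)sulfonyl)oxy in place of (4-aminophenyl)amino on this aromatic carbon gives an at least 2.8-fold higher number from compound 1 to compound 3 (0.45 log units; beyond the scatter), the first sign that this position responds to what it carries. The true size of the step stays unknown, since the reading stops at the limit: the limit of > 20000 nM in this assay, at which 1 of the 3 values shown sits.

From the compounds shown here alone, whether a methoxy group or a short alkyl chain here would give a lower or higher number remains open. Both groups shown carry a six-membered aromatic ring, so the role of that ring also stays unresolved.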